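The compounds below may be only part of what the source reports. "The series", "measured", "known", "first", "only" and "open" are said of these compounds alone.

Compound 3 `O=c1c(Cc2coc3ccccc3c2=O)coc2ccccc12` gives 7400 nM in a functional assay on PC-3 cells (Homo sapiens) for antiproliferative activity, read by XTT assay (on this read-out lower numbers stand for stronger inhibition and higher numbers for weaker inhibition), the higher of the two numbers shown. Compound 2 `Cc1ccc2c(=O)c(Cc3coc4cccc(OCC5CCCCC5)c4c3=O)coc2c1` gives 2440 nM in this assay. Compound 1 `CC(C)CCOc1cccc2occ(Cc3coc4ccccc4c3=O)c(=O)c12` reaches only the limit of this assay, at > 10000 nM. Going by the values given here, the one measured step that touches the same place is an at least 1.3-fold lower number from compound 1 to compound 3 (0.13 log units; that floor lies within the scatter), where the alkoxy chain left; its size is known only as a floor, because compound 1 sits at the limit of > 10000 nM in this assay, at which 1 of the 3 values shown sits. Compound 4 `COc1cccc2occ(Cc3coc4ccccc4c3=O)c(=O)c12` carries methoxy in place of hydrogen on an aromatic carbon. A methoxy entering where an isopentyloxy had given no measurable number suggests, at most, a modest rise and perhaps no step beyond the scatter. Compound 4 is therefore expected to show a step of a 1.3-fold higher number from compound 3 to compound 4 (0.11 log units; within the scatter), giving an estimated 9500 nM, in the range 3500 nM to 25000 nM.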

Compound 4, half-maximal inhibitory concentration: 3490 nM
Compound 4: middle estimate off by 2.7-fold (0.43 log units), on the high side; the measured number lies below the stated range.
By their numbers in this assay, from the lowest: compounds 2 and 4 (each within the scatter of the next); then compound 3. At a limit, above all of these: compound 1.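

In this assay, going by these compounds alone, methoxy in place of hydrogen on this aromatic carbon gives a 2.1-fold lower number from compound 3 to compound 4 (0.33 log units; beyond the scatter) and so supplies the first step at this position with a measured number at both ends. Cutting the isopentyloxy chain back to methoxy, with hydrogen in place of isobutyl, gives an at least 2.8-fold lower number from compound 1 to compound 4 (0.45 log units; beyond the scatter) and shows that the chain length matters here. That step is only a floor because compound 1 stands at a limit: the limit of > 10000 nM in this assay, at which 1 of the 4 values shown sits.

The compounds shown leave open whether ethoxy, hydroxyl or an amine at this place would behave like methoxy or like isopentyloxy.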